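Aryl piperazine oxindoles: phenyl replacing chloromethylphenyl

The source may report more compounds than this note shows. Statements on the series, on what has been measured and on what is new or still open speak of the compounds shown alone.

Three members of the series have been run in a functional assay on the whole organism (strain Wistar) with Rattus norvegicus as the target, with a stated time of 5 min (a higher number here means that more compound is needed for the effect, a lower number that less compound is needed), and every one returned a limit rather than a number. Compound 1 `CCC1(CCCCN2CCN(c3ccc(C)c(Cl)c3)CC2)C(=O)Nc2ccccc21` gives > 20 mg/kg in this assay, which is a limit of the assay. Compound 2 `O=C1Nc2ccc(F)cc2C1CCCCN1CCN(c2ccc(F)cc2)CC1` gives > 10 mg/kg in this assay, again a limit. Compound 3 `CCC1(CCCCN2CCN(c3ccc(Cl)cc3)CC2)C(=O)Nc2cc(F)ccc21` gives > 20 mg/kg in this assay, also a limit. Among the measured compounds shown here, the picture is summarised by the limit of > 20 mg/kg in this assay, at which 2 of the 3 values shown sit, and by the limit of > 10 mg/kg in this assay, at which 1 of the 3 values shown sits, so compound 1 stands with the others at the edge of what the assay reports, and no step between measured compounds can be sized.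

Compound 4 `CCC1(CCCCN2CCN(c3ccccc3)CC2)C(=O)Nc2ccccc21` is the next member. Relative to compound 1 the change is phenyl in place of 3-chloro-4-methylphenyl on an amine nitrogen in a ring. For the measured compounds named here, with no measured step to lean on and all three known values sitting at limits, no direction can be read from the data; the expectation for the step from compound 1 to compound 4 is a number no higher from compound 1 to compound 4 (the limit leaves the size open), that is, nothing beyond the usual scatter. Compound 4 is therefore expected to give about 20 mg/kg in this assay, within 5 mg/kg to 40 mg/kg, most likely again reported only as a limit.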

Compound 4, minimum effective dose: 10 mg/kg
For compound 4 the middle estimate is 2.0-fold (0.30 log units) above the measured one; the range from low to high includes it.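

Of the four members shown, only compound 4 returns a number in this assay: compound 4 gives 10 mg/kg. Going by these compounds, on the amine nitrogen in a ring, phenyl in place of 3-chloro-4-methylphenyl gives an at least 2.0-fold lower number from compound 1 to compound 4 (0.30 log units; that floor lies within the scatter); compound 1 carries only a limit, so this is a floor, the true size of the step is unknown, and the printed floor does not by itself separate the two compounds beyond the scatter. The unsubstituted phenyl is thus the only aryl group at this position shown with a measured dose, while the remaining values stay at the edge of what the assay reports: the limit of > 20 mg/kg in this assay, at which 2 of the 4 values shown sit.

Steps involving compound 2 or compound 3 cannot be read, since each differs from compound 4 and from compound 1 in more than one place and each carries only a limit. Also open, on these data alone, is which part of 3-chloro-4-methylphenyl matters for the step, a question that 3-chlorophenyl and 4-methylphenyl at the same nitrogen would address, along with whether a 2-pyridyl ring or a 4-methoxyphenyl group there would hold a measurable dose.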